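Removing the methoxy group from the carboxyphenyl arm

The source may hold more compounds than are shown below. What is called first, only, known or untested is meant among the compounds shown, and "the series" means these compounds.

Of the compounds shown here, three sharing one core have been measured in an assay on isolated protein for activation of cGMP-dependent protein kinase 1 (Homo sapiens), read by ADP-Glo, with stated times of 120 min and 40 min; on this read-out lower numbers stand for an effect already at smaller amounts and higher numbers for an effect only at larger amounts of compound. Compound 1 `O=C(O)c1ccc(CN2CCC[C@H](OCc3cc(Cl)cc(Cl)c3)[C@@H]2c2ccccc2)s1` gives 76000 nM. Compound 2 `O=C(O)c1ccc(CN2CCC[C@H](O[C@H](CO)c3cc(Cl)cc(Cl)c3)[C@@H]2c2ccccc2)cc1` gives 11000 nM. Compound 3 `COc1ccc(C(=O)O)cc1CN1CCC[C@H](OCc2cc(Cl)cc(Cl)c2)[C@@H]1c1ccccc1` gives 123000 nM, the highest of the three numbers; its nearest neighbour is compound 1, which stands within the scatter of it, while compound 2 lies well beyond the scatter at a lower number.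

Compound 4 `O=C(O)c1ccc(CN2CCC[C@H](OCc3cc(Cl)cc(Cl)c3)[C@@H]2c2ccccc2)cc1` has not yet been measured. It differs from compound 3 in one place: 4-carboxyphenyl in place of 5-carboxy-2-methoxyphenyl on a saturated chain carbon bound to an amine nitrogen in a ring. Among the measured compounds shown here, only one measured step touches this part of the molecule, the exchange of the arm between compound 1 and compound 3, which gave a 1.6-fold higher number from compound 1 to compound 3 (0.21 log units; within the scatter). For the measured compounds named here, no measured pair shows what the methoxy group alone contributes; compound 2 carries a different arm and a further change elsewhere, so its value cannot be tied to this step. With only a within-scatter step to go on, the expected change from compound 3 to compound 4 is a 1.8-fold lower number from compound 3 to compound 4 (0.24 log units; within the scatter), that is, no shift beyond the scatter. Compound 4 is therefore estimated at 70000 nM, with a range from 20000 nM to 250000 nM.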

Compound 4, half-maximal effective concentration: 76000 nM
Beside the measured number, compound 4's estimate is 1.1-fold (0.04 log units) below it; the range from low to high includes it.
By their numbers in this assay, from the lowest: compound 2; then compounds 1, 4 and 3 (each within the scatter of the next).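

Taking the methoxy group off the arm gives a 1.6-fold lower number from compound 3 to compound 4 (0.21 log units; within the scatter) in this assay and so does not move the number by more than the scatter. The arm can also change from 5-carboxythiophen-2-yl to 4-carboxyphenyl with no change at the digits printed from compound 1 to compound 4 (within the scatter) and the result stands unchanged, so the three arms tested cannot be told apart here. Among the compounds shown here, the one step beyond the scatter lies elsewhere: hydrogen in place of hydroxymethyl, on a saturated chain carbon bound to an aromatic carbon and an oxygen on a saturated carbon, gives a 6.9-fold higher number from compound 2 to compound 4 (0.84 log units; beyond the scatter) with the arm held the same, which ties the gap of compound 2 to the hydroxymethyl group and not to the arm.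

Still open, going by these compounds, is whether an arm with a tetrazole or a primary amide in place of the carboxylic acid would keep a number in this range. On these data alone, it is also open whether the hydroxymethyl step would be the same size on the 5-carboxythiophen-2-yl arm or the 5-carboxy-2-methoxyphenyl arm. Nothing available explains why any of these steps comes out as it does.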